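The compounds below may be only part of what the source reports. "The series", "measured", "known", "first", "only" and "open" are said of these compounds alone.

Measured in a functional assay on HCT-116 cells (Homo sapiens) for antiproliferative activity, read by MTT assay, with a stated time of 48 h; a lower number here means a stronger inhibitor, a higher number a weaker inhibitor:
compound 1 `CCCC(CCO)n1cnc2c(Cl)ncnc21`: > 50000 nM
compound 2 `CCCCCCCCCC(CCO)n1cnc2c(Cl)nc(F)nc21`: 32100 nM

The entry for compound 1, > 50000 nM, is a limit of the assay and not a number. Going by the values given here, compound 2, at 32100 nM, holds the only true number so far in this assay.

Compound 3 `CCCCCCCCCC(CCO)n1cnc2c(Cl)ncnc21` differs from compound 2 by hydrogen in place of fluoro on an aromatic carbon, between two ring nitrogen atoms. Among the compounds with values here, no measured pair shows this change, so no step beyond the scatter is expected, in either direction. The estimated 1.1-fold lower number from compound 2 to compound 3 (0.03 log units; within the scatter) stays within the scatter. Compound 3 is expected at 30000 nM, with an estimated range of 12000 nM to 50000 nM.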

Compound 3, half-maximal inhibitory concentration: 890 nM
The estimate for compound 3 lay 34-fold (1.53 log units) above the measured number; the whole stated range lies above it.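

In this assay, the aromatic carbon between two ring nitrogen atoms proves sensitive to its substituent: hydrogen in place of fluoro gives a 36-fold lower number from compound 2 to compound 3 (1.56 log units; beyond the scatter). The chain matters too, with hexyl in place of hydrogen on a saturated chain carbon giving an at least 56-fold lower number from compound 1 to compound 3 (1.74 log units; beyond the scatter). Compound 1 holds a limit of the assay, not a number: the limit of > 50000 nM in this assay, at which 1 of the 3 values shown sits.

On these data alone, whether an amine or a methyl group on that aromatic carbon would keep the number of compound 3 remains open. So does the outcome of a longer chain, or of a carboxylic acid in place of the chain's hydroxyl.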